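The source may report more compounds than this note shows. Statements on the series, on what has been measured and on what is new or still open speak of the compounds shown alone.

Measured in a functional assay on Jurkat cells (Homo sapiens) for cytotoxicity, with a stated time of 48 h; a higher number here means a weaker inhibitor, a lower number a stronger inhibitor:
- compound 1 `CCCc1ccc2c(c1)C(CC(=O)OCC)C(C(=O)OCC)=C(N)O2`: 57300 nM
- compound 2 `CC(C)OC(=O)CC1C(C(=O)OC(C)C)=C(N)Oc2ccc(-c3ccccc3)cc21`: 38700 nM
- compound 3 `CCOC(=O)C1=C(N)Oc2ccc(-c3ccccc3)cc2C1CC(=O)N1CCOCC1`: > 100000 nM (a limit, not a number)

Compound 1 at 57300 nM and compound 2 at 38700 nM lie within the scatter of each other. Among the compounds with values here, these are the only two numbers, so compound 1 sits level with the one comparison available.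

Compound 4 `CCOC(=O)CC1C(C(=O)OCC)=C(N)Oc2ccc(-c3ccc4ccccc4c3)cc21` keeps the core of compound 1 and carries naphthalen-2-yl in place of propyl on an aromatic carbon.

Within the data shown here, no two measured compounds differ in one place only, so no measured step guides this change. Compound 2 at 38700 nM gives no sign of a large shift from compound 1, although the two differ in more than one place. A modest move towards a lower number in this assay is therefore expected, and a result within the scatter would be no surprise.

The expected change is a 2.6-fold lower number from compound 1 to compound 4 (0.42 log units; beyond the scatter).

For compound 4 the estimated value is 22000 nM, with an expected range of 8000 nM to 60000 nM.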

Compound 4, half-maximal inhibitory concentration: 18700 nM
Compound 4: middle estimate off by 1.2-fold (0.07 log units), on the high side; measured number inside the range.
By their numbers in this assay, from the lowest: compound 4; then compounds 2 and 1 (each within the scatter of the next). At a limit, above all of these: compound 3.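

In this assay, within the data shown here, this aromatic carbon of the shared core accepts a far larger group than propyl with no loss: naphthalen-2-yl, with 10 heavy atoms against 3, gives a 3.1-fold lower number from compound 1 to compound 4 (0.49 log units; beyond the scatter) as the first step that changes one place only. The step is modest, and compound 4 still stands at 18700 nM, so the change shifts the number without bringing it into a low range. No measured property in hand bears on the reason for this shift.

Open, from the compounds shown here alone, is whether the step follows the added aromatic ring or simply the size of the group, which a longer alkyl chain at this carbon would separate. Also open, going by these compounds, is how an amine or a carboxylic acid on the aromatic ring at this position would read in this assay.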